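This account rests on a few compounds, and the source may have more. Where it says the series, first, only, none or still open, it means among the compounds named here.

Compound 1 `O=C1NCCc2nc(C#Cc3ccccc3)sc21`: > 10000 nM
Compound 2 `CC(C)CN1CCc2nc(C#Cc3ccccc3)sc2C1`: 650 nM

In an assay on HEK293 cells for negative allosteric modulation of metabotropic glutamate receptor 5 (Homo sapiens), read by FLIPR, with a stated time of 1 h (on this read-out higher numbers stand for weaker inhibition and lower numbers for stronger inhibition), compound 1 gives only a limit, > 10000 nM, so no number is known for it (the limit of > 10000 nM in this assay, at which 1 of the 2 values shown sits). Compound 2 gives 650 nM in this assay, and this is the only actual number among the two compounds shown, so there is nothing yet to set it against. Compound 3 `CC1CC1C(=O)N1CCc2nc(C#Cc3ccccc3)sc2C1` has not been measured. It differs from compound 2 in one place (2-methylcyclopropyl)carbonyl in place of isobutyl on an amine nitrogen in a ring: the (2-methylcyclopropyl)carbonyl brings one hydrogen-bond acceptor and a three-membered ring where the isobutyl had neither. Among the measured compounds shown here, no measured pair shows the effect of this kind of change, so the expectation rests on compound 2 alone. For compound 3 the step of a 3.3-fold lower number from compound 2 to compound 3 (0.51 log units; beyond the scatter) is expected to be modest and toward stronger inhibition, with wide uncertainty. Compound 3 is estimated at 200 nM, between 30 nM and 1500 nM.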

Compound 3, half-maximal inhibitory concentration: > 10000 nM
Compound 3 was reported as a limit (the forecaster's own chance of this, stated with the estimate: 10%); at least 50-fold (1.69 log units) between middle value and limit.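

On the amine nitrogen in the ring, putting (2-methylcyclopropyl)carbonyl in place of isobutyl gives an at least 15-fold higher number from compound 2 to compound 3 (1.18 log units; beyond the scatter) in this assay. This position is therefore not indifferent to what sits on it: this single change takes the series from a measurable inhibitor to one with no measurable value in this assay. Compound 3 gives only a limit, not a number, so the full size of the step remains unknown: the limit of > 10000 nM in this assay, at which 2 of the 3 values shown sit.

The carbonyl and the three-membered ring enter together, and the compounds shown cannot tell which of them goes with the loss. A cyclopropylmethyl group, with the ring but no carbonyl, and an acetyl group, with the carbonyl but no ring, would separate the two.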